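The source may hold more compounds than are shown below. What is called first, only, known or untested is meant among the compounds shown, and "the series" means these compounds.

Compounds measured so far in a functional assay on MCF7 cells (Homo sapiens) for antiproliferative activity, read by MTT assay, with a stated time of 48 h; a higher number here means a weaker inhibitor, a lower number a stronger inhibitor:
Compound 1 `COc1ccc(-c2c(Nc3ccc(F)cc3)c3ccc(O)cc3oc2=O)cc1` gives 71500 nM.
Compound 2 `COc1ccc(-c2c(Nc3ccc(C)c(O)c3)c3ccc(O)cc3oc2=O)cc1` gives only a limit of the assay, > 100000 nM.
Compound 3 `COc1ccc2oc(=O)c(C(=O)C(F)(F)F)c(Nc3ccc(F)cc3)c2c1` also gives only a limit of the assay, > 100000 nM.

Compound 1 and compound 2 share one core and differ in a single place: 3-hydroxy-4-methylphenyl in place of 4-fluorophenyl on a nitrogen on an aromatic ring. That change produced an at least 1.3-fold higher number from compound 1 to compound 2 (0.14 log units; that floor lies within the scatter). Its true size is not known, since compound 2 sits at the limit of > 100000 nM in this assay, at which 2 of the 3 values shown sit, so only a floor can be stated for this step.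

Compound 4 `COc1ccc2oc(=O)c(C(=O)C(F)(F)F)c(Nc3ccc(C)c(O)c3)c2c1` has not yet been measured. It stands to compound 3 exactly as compound 2 stands to compound 1: 3-hydroxy-4-methylphenyl in place of 4-fluorophenyl on a nitrogen on an aromatic ring. The surroundings of the place are the same in both pairs, so this is the same change made on a second core. The two cores, that of compound 1 and that of compound 3, differ, and the difference between them is not broken down here.

In this assay the expected step is a step that the limit leaves unreadable from compound 3 to compound 4, resting on an at least 1.3-fold higher number from compound 1 to compound 2 (0.14 log units; that floor lies within the scatter) and on compound 3 already standing at the limit of > 100000 nM in this assay, at which 2 of the 3 values shown sit. Compound 4 is therefore estimated at 150000 nM, with a range from 60000 nM to 500000 nM, and the assay is expected most often to report only a limit for compound 4.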

Compound 4, half-maximal inhibitory concentration: 20100 nM
Beside the measured number, compound 4's estimate is 7.5-fold (0.87 log units) above it, and the stated range ends above it.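

In this assay, putting 3-hydroxy-4-methylphenyl in place of 4-fluorophenyl on the core of compound 3 gave an at least 4.9-fold lower number from compound 3 to compound 4 (0.69 log units; beyond the scatter), so on this core the change goes with a stronger inhibitor. This result cannot simply be carried over from the core of compound 1, where the same change did not give a lower number, and the two outcomes differ by more than repeated measurements would explain: the same change on two cores in this assay, an at least 1.3-fold higher number (0.14 log units; that floor lies within the scatter) from compound 1 to compound 2 and an at least 4.9-fold lower number (0.69 log units; beyond the scatter) from compound 3 to compound 4, at least 6.9-fold (0.84 log units) apart, beyond the scatter of two such steps What this does not show is why the two cores respond differently or how large either step truly is, as each step has one compound standing at a limit of the assay, so only a floor can be given for each: the limit of > 100000 nM in this assay, at which 2 of the 4 values shown sit.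

The compounds shown leave open whether the hydroxy group, the methyl group or the two together go with the lower number for compound 4, and whether the loss of the fluorine plays any part. Also open, as far as these compounds go, is how a ring carrying an amine or a carboxylic acid in this place would behave on either core, and which of the two outcomes a third core would follow.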